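Bromo on the sulfonyl phenyl: compound 3 to compound 4

The source may hold more compounds than are shown below. What is called first, only, known or untested is meant among the compounds shown, and "the series" means these compounds.

Measured so far:
- compound 1 `CN(C(=O)c1ccc(F)cc1)c1ccc2[nH]c(-c3n[nH]c4ccccc34)cc2n1`: 1210 nM
- compound 2 `COc1ccc(C(=O)N(C)c2ccc3[nH]c(-c4n[nH]c5ccccc45)cc3n2)cc1`: 3320 nM
- compound 3 `CN(c1ccc2[nH]c(-c3n[nH]c4ccccc34)cc2n1)S(=O)(=O)c1ccccc1`: 3700 nM

In a functional assay on HL-60 cells (Homo sapiens) for antiproliferative activity, read by MTT assay, with a stated time of 72 h (on this read-out higher numbers stand for weaker inhibition and lower numbers for stronger inhibition), compound 3 gives 3700 nM, the highest of the three numbers; the step of a 3.1-fold higher number from compound 1 to compound 3 (0.49 log units; beyond the scatter) lies beyond the scatter, while the step of a 1.1-fold higher number from compound 2 to compound 3 (0.05 log units; within the scatter) lies within it, so compound 2 and compound 3 cannot be told apart here.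

Compound 4 `CN(c1ccc2[nH]c(-c3n[nH]c4ccccc34)cc2n1)S(=O)(=O)c1ccc(Br)cc1` differs from compound 3 in one place: bromo in place of hydrogen on an aromatic carbon, placed on an aromatic carbon of a six-membered aromatic ring of carbon only, para to a large group.

Among the compounds with values here, no measured step adds a bromo, and none changes a substituent on the phenylsulfonyl group. The nearest parallel is the step of a 2.7-fold higher number from compound 1 to compound 2 (0.44 log units; beyond the scatter), where a group on the aryl of the carbonyl was exchanged, with a modest effect. That exchange is not the same as adding bromo to the sulfonyl phenyl, so it offers only a loose guide.

Compound 4 is therefore expected to give a number close to that of compound 3, a step of a 1.2-fold lower number from compound 3 to compound 4 (0.09 log units; within the scatter) in this assay, with an estimate of 3000 nM (range 1200 nM to 8000 nM).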

Compound 4, half-maximal inhibitory concentration: 6240 nM
Compound 4: the middle estimate sits 2.1-fold (0.32 log units) below what was measured; low and high end bracket the measured number.
By their numbers in this assay, from the lowest: compound 1; then compounds 2, 3 and 4 (each within the scatter of the next).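

Bromo in place of hydrogen on the sulfonyl phenyl is the first change at this position, and in this assay it gives a step that lies within the scatter (a 1.7-fold higher number from compound 3 to compound 4 (0.23 log units; within the scatter)), so this position accepts a bromine without a change that can be told apart. The swap from the (4-methoxyphenyl)carbonyl group to the (4-bromophenyl)sulfonyl group also stays within the scatter (a 1.9-fold higher number from compound 2 to compound 4 (0.27 log units; within the scatter)), while the swap from the (4-fluorophenyl)carbonyl group lies beyond it (a 5.2-fold higher number from compound 1 to compound 4 (0.71 log units; beyond the scatter)), leaving compound 1 still apart from compound 4. Nothing measured here explains these steps.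

The compounds shown leave open how an amine or a carboxylic acid at this same place would read. They also leave open whether a bromo on the phenyl of the carbonyl compounds would behave as it does here.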